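The source may hold more compounds than are shown below. What is called first, only, known or untested is meant among the compounds shown, and "the series" means these compounds.

Of the compounds shown here, two built on one shared core have numbers so far in a functional assay on HT-29 cells (Homo sapiens) for antiproliferative activity, read by sulforhodamine B assay, with a stated time of 48 h; on this read-out lower numbers stand for stronger inhibition and higher numbers for weaker inhibition: compound 1 `Cc1ccc(NS(=O)(=O)c2ccc(N3CCNC3=O)cc2)cc1C` gives 230 nM, and compound 2 `CCCCOc1ccc(NS(=O)(=O)c2ccc(N3CCNC3=O)cc2)cc1` gives 630 nM. Compound 2 therefore holds the higher of the two numbers, which means the weaker inhibition, and the gap between them lies beyond the usual scatter of repeated measurements.

Compound 3 `COc1ccc(NS(=O)(=O)c2ccc(N3CCNC3=O)cc2)cc1` has not yet been measured. It keeps the frame of compound 2 but trades butoxy for methoxy: hydrogen in place of propyl on a saturated chain carbon bound to an oxygen on an aromatic ring.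

Within the data shown here, no tested pair differs in this one place alone, so the evidence for any forecast is thin. Compound 1, which carries no butoxy group, reads 230 nM, a modest hint that losing the long chain could lower the number. A small step toward stronger inhibition is expected, and it may not clear the scatter. The estimated change is a 1.4-fold lower number from compound 2 to compound 3 (0.15 log units; within the scatter). In this assay the expected value of compound 3 is 450 nM, with an estimated range from 150 nM to 1400 nM.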

Compound 3, half-maximal inhibitory concentration: 800 nM
Beside the measured number, compound 3's estimate is 1.8-fold (0.25 log units) below it; the measured number falls inside the stated range.
By their numbers in this assay, from the lowest: compound 1; then compounds 2 and 3 (each within the scatter of the next).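

At this place, the chain on the oxygen can be cut from butyl to methyl with no clear effect in this assay: the step is a 1.3-fold higher number from compound 2 to compound 3 (0.10 log units; within the scatter), so butoxy and methoxy cannot be told apart on this read-out. The step that does clear the scatter lies at the whole group on the sulfonamide nitrogen, where 4-methoxyphenyl in place of 3,4-dimethylphenyl gives a 3.5-fold higher number from compound 1 to compound 3 (0.54 log units; beyond the scatter), which shows that a long chain is not needed for a number well above that of compound 1. No measurement at hand accounts for either result.

The compounds shown leave open whether an amine or a carboxylic acid in place of the butoxy or methoxy group would read apart from these two, and whether a chain longer than butyl would still make no clear difference. Also open, from the compounds shown here alone, is whether the step on the sulfonamide nitrogen would hold on the same scale in cells other than HT-29.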